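This account rests on a few compounds, and the source may have more. Where it says the series, first, only, none or still open, it means among the compounds named here.

Measured compounds:
Compound 1 `COC(=O)CCC(=O)Nc1cccc(OCc2ccc3ccccc3n2)c1` gives 28000 nM in an assay on isolated protein for inhibition of Polyunsaturated fatty acid 5-lipoxygenase (Rattus norvegicus); a higher number here means a weaker inhibitor, a lower number a stronger inhibitor.
Compound 2 `COC(=O)CCC(=O)N(O)c1cccc(OCc2ccc3ccccc3n2)c1` gives 1400 nM in this assay.
Compound 3 `COC(=O)CCC(=O)Nc1cc(OCc2ccc3ccccc3n2)ccc1C` gives 7600 nM in this assay.

Compound 1 has the highest number of the three, which makes it the weakest inhibitor shown. Its nearest neighbour is compound 3, reached by a 3.7-fold lower number from compound 1 to compound 3 (0.57 log units; beyond the scatter); the furthest is compound 2, reached by a 20-fold lower number from compound 1 to compound 2 (1.30 log units; beyond the scatter). Both steps touch the side chain that hangs from the shared core, and both push the number down.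

Compound 4 `COC(=O)CCNC(=O)c1cccc(OCc2ccc3ccccc3n2)c1` keeps every atom of compound 1 but joins them differently: (2-(methoxycarbonyl)ethyl)carbamoyl in place of ((2-(methoxycarbonyl)ethyl)carbonyl)amino on an aromatic carbon. The chain and its ester are unchanged; what changes is that the amide is turned around, so the nitrogen now sits on the chain side and the carbonyl on the ring side, while the hydrogen-bond donor and acceptor count stays the same.

Among the measured compounds shown here, no measured step turns the amide around, so neither step above bears on this change directly; they only show that this region of compound 1 can be altered with effects ranging from modest to large, and always downward. Without a matching precedent, the expected step of no change at the digits printed from compound 1 to compound 4 (within the scatter) is one of no clear direction beyond the scatter. Compound 4 is therefore estimated at 28000 nM, within a range from 8000 nM to 90000 nM.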

Compound 4, half-maximal inhibitory concentration: 35200 nM
Compound 4: middle estimate off by 1.3-fold (0.10 log units), on the low side; the measured number falls inside the stated range.
By their numbers in this assay, from the lowest: compound 2; then compound 3; then compounds 1 and 4 (each within the scatter of the next).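

Turning the amide around gives a 1.3-fold higher number from compound 1 to compound 4 (0.10 log units; within the scatter) in this assay, so at this place on the aromatic ring, the direction of the amide link does not separate these two compounds. This is the first listed change to compound 1 that leaves the number within the scatter, unlike the earlier steps, a 20-fold lower number from compound 1 to compound 2 (1.30 log units; beyond the scatter) and a 3.7-fold lower number from compound 1 to compound 3 (0.57 log units; beyond the scatter); the downward trend seen so far therefore does not extend to compound 4. Nothing available here explains why the reversal leaves the number where it is.

Still open, going by these compounds, is whether the reversed amide would respond to the same changes as compound 1, such as a hydroxy on its nitrogen or a methyl on the aromatic ring. The compounds shown also leave open what a carboxylic acid in place of the methoxycarbonyl group, or a longer chain carrying that group, would do to the number with either direction of the amide.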